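Methylating the Amide Nitrogen of a Fatty Acid Receptor Agonist

The compounds below may be only part of what the source reports. "The series", "measured", "known", "first", "only" and "open" are said of these compounds alone.

Compound 1 `O=C(O)COc1ccc(NCc2cccc(Oc3ccccc3)c2)cc1`: 2040 nM in a functional assay on CHO cells for agonist activity at Free fatty acid receptor 1 (Homo sapiens); on this read-out lower numbers stand for an effect already at smaller amounts and higher numbers for an effect only at larger amounts of compound
Compound 2 `NC(=O)CCc1ccc(NCc2cccc(Oc3ccccc3)c2)cc1`: 51.3 nM in this assay

Compound 2 gives the lowest number of the two measured. Among the measured compounds shown here, the only step known here is a 40-fold lower number from compound 1 to compound 2 (1.60 log units; beyond the scatter), with 2-carbamoylethyl in place of carboxymethoxy. Compound 3 `CNC(=O)CCc1ccc(NCc2cccc(Oc3ccccc3)c2)cc1` keeps that amide chain but carries methyl in place of hydrogen on an amide-type nitrogen. For the measured compounds named here, no measured step touches the amide nitrogen itself, so the large step between compound 1 and compound 2 gives only loose guidance. Such a small change is expected to shift the read-out little, if anything toward a higher number. Compound 3 is therefore estimated at 70 nM (range 25 nM to 250 nM), an expected step of a 1.4-fold higher number from compound 2 to compound 3 (0.13 log units; within the scatter), within the scatter.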

Compound 3, half-maximal effective concentration: 49 nM
Estimate against measurement, compound 3: 1.4-fold (0.15 log units) above, within the range that was stated.
By their numbers in this assay, from the lowest: compounds 3 and 2 (each within the scatter of the next); then compound 1.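

The amide nitrogen accepts methyl in place of hydrogen: in this assay the result is a 1.0-fold lower number from compound 2 to compound 3 (0.02 log units; within the scatter). The large difference from the carboxymethoxy chain also remains with the methylated amide, at a 42-fold lower number from compound 1 to compound 3 (1.62 log units; beyond the scatter). No supporting data are available to explain why the added methyl makes so little difference. Going by these compounds, it remains open whether this nitrogen would accept an ethyl group or a second methyl equally well. Also open, on these data alone, is how a carboxylic acid at the end of the same chain would compare.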